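Moving the methyl on the pyridine in the pyrrolidine series

A few compounds are considered here, and "the series" means these few. Any claim that something is new, unique, unknown or untested is made for them only; others in the source may bear on it.

Compound 1 `Cc1nc(CN2CCC[C@H]2c2ccccn2)cc(N2CCN(C)CC2)n1`: 2.7 nM
Compound 2 `Cc1ccnc([C@@H]2CCCN2Cc2cc(N3CCN(C)CC3)nc(C)n2)c1`: "not determined" (no result reported)
Compound 3 `Cc1ccc([C@@H]2CCCN2Cc2cc(N3CCN(C)CC3)nc(C)n2)nc1`: to be measured

The shared core of compound 1 and compound 2 differs only in the pyridine carried on the saturated ring carbon. In a functional assay on cells (T cell) for antagonist activity at C-X-C chemokine receptor type 4 (Homo sapiens), read by FLIPR and calcium flux, with a stated time of 20 min (a higher number here means a weaker inhibitor, a lower number a stronger inhibitor), compound 1 gives 2.7 nM. In this assay compound 2 stands at "not determined" (no result reported); no result was reported, so nothing can be said about where the methyl on the pyridine leaves it relative to compound 1.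

Compound 3 is the positional isomer of compound 2: 5-methylpyridin-2-yl in place of 4-methylpyridin-2-yl on a saturated ring carbon. Among the compounds with values here, with no number for compound 2, no step between them can be computed, and no step from a measured pair exists to set a size or direction for this change. Within the data shown here, the only anchor is compound 1, whose pyridine carries no methyl.

Compound 3 is expected to land near compound 1, since compound 1 reaches 2.7 nM in this assay and the remainder of the molecule is unchanged. Compound 3 is estimated at 6 nM, with a range from 1.5 nM to 40 nM in this assay.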

Compound 3, half-maximal inhibitory concentration: 4.9 nM
For compound 3 the middle estimate is 1.2-fold (0.09 log units) above the measured one; measured number inside the range.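

Within the data shown here, compound 3 is the only compound here with a methyl on the pyridine and a reported number, so it gives the series its sole reading of this change: in this assay, methyl in place of hydrogen on an aromatic carbon gives a 1.8-fold higher number from compound 1 to compound 3 (0.26 log units; within the scatter). On a saturated ring carbon of the pyrrolidine, next to the ring nitrogen, the 5-methylpyridin-2-yl group therefore cannot be told apart from the unsubstituted pyridine of compound 1 in this read-out, and the methyl is tolerated here with the rest of the molecule unchanged. This rests on a single pair, and no measurement at hand accounts for the result.

Going by these compounds, the step between compound 2 and compound 3 cannot be read, so the swap of 4-methylpyridin-2-yl for 5-methylpyridin-2-yl has neither a size nor a direction, and it stays unknown whether the placing of the methyl on the pyridine matters at all. The compounds shown also leave open whether a group other than methyl, such as an ethyl, a methoxy or a carboxylic acid, would keep the number in the same range as compound 1 and compound 3.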